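A few compounds are considered here, and "the series" means these few. Any claim that something is new, unique, unknown or untested is made for them only; others in the source may bear on it.

In a functional assay on HeLa cells (Homo sapiens) for antiproliferative activity, read by cell counting, with a stated time of 3 days (a lower number here means a stronger inhibitor, a higher number a weaker inhibitor), compound 1 `COc1ccc(Oc2ccccc2NC(C)=C2C(=O)CC(c3ccccc3)CC2=O)cc1OC` gives 54 nM. Among the measured compounds shown here, the only other measured compound, compound 2 `CC(Nc1ccccc1Oc1ccccc1)=C1C(=O)CC(c2ccccc2)CC1=O`, gives 79 nM, and these two values lie within the usual scatter of each other. Compound 3 `COc1cccc(Oc2ccccc2NC(C)=C2C(=O)CC(c3ccccc3)CC2=O)c1` has not yet been measured. It differs from compound 1 in one place, with hydrogen in place of methoxy on an aromatic carbon. This turns 3,4-dimethoxyphenoxy into 3-methoxyphenoxy. For the measured compounds named here, one measured step bears on the change: phenyl in place of 3,4-dimethoxyphenyl, which removes both methoxy groups, gave a 1.5-fold higher number from compound 1 to compound 2 (0.17 log units; within the scatter). Going by the values given here, compound 3 loses only one of those groups, so no step beyond the scatter is expected in this assay. Compound 3 is expected at 65 nM, with an estimated range of 35 nM to 120 nM. The expected change is a 1.2-fold higher number from compound 1 to compound 3 (0.08 log units; within the scatter).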

Compound 3, half-maximal inhibitory concentration: 93 nM
Compound 3: middle estimate off by 1.4-fold (0.16 log units), on the low side; measured number inside the range.
By their numbers in this assay, from the lowest: compounds 1, 2 and 3 (each within the scatter of the next).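

In this assay, hydrogen in place of the methoxy group that sits para to a large group gives a 1.7-fold higher number from compound 1 to compound 3 (0.24 log units; within the scatter) and turns 3,4-dimethoxyphenoxy into 3-methoxyphenoxy. Methoxy in place of hydrogen on the plain phenyl gives a 1.2-fold higher number from compound 2 to compound 3 (0.07 log units; within the scatter) and so shows that the single methoxy group of 3-methoxyphenoxy, like the loss of one group from 3,4-dimethoxyphenoxy, stays within the scatter, something the earlier step removing both groups at once could not separate. No measurement here offers an explanation for these numbers.

Only methoxy and hydrogen have been compared on this aromatic carbon, so the compounds shown leave open what a clearly different group, such as an amine or a carboxylic acid, would do there. A longer chain, such as ethoxy in place of methoxy, also remains an open question.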